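A few compounds are considered here, and "the series" means these few. Any claim that something is new, unique, unknown or untested is made for them only; others in the source may bear on it.

Measured so far:
compound 1 `c1ccc(-c2cc(-c3cnn(C4CCNCC4)c3)on2)cc1` gives 100000 nM in an assay on isolated protein for positive allosteric modulation of Neuronal acetylcholine receptor; alpha4/beta2 (Homo sapiens); on this read-out higher numbers stand for an effect only at larger amounts of compound and lower numbers for an effect already at smaller amounts.
compound 2 `Fc1cccc(Cl)c1-c1cc(-c2cnn(C3CCNCC3)c2)on1` gives 48 nM.
compound 3 `Fc1cccc(-c2cc(-c3cnn(C4CCNCC4)c3)on2)c1Cl` gives 230 nM.

Compound 3 stands second highest of the three numbers; nearest is compound 2 (a 4.8-fold higher number from compound 2 to compound 3 (0.68 log units; beyond the scatter)), furthest is compound 1 (a 430-fold lower number from compound 1 to compound 3 (2.64 log units; beyond the scatter)). Compound 4 `Clc1cnccc1-c1cc(-c2cnn(C3CCNCC3)c2)on1` differs from compound 3 by 3-chloropyridin-4-yl in place of 2-chloro-3-fluorophenyl on an aromatic carbon. Among the measured compounds shown here, the steps that bear on this are a 2100-fold lower number from compound 1 to compound 2 (3.32 log units; beyond the scatter) and a 430-fold lower number from compound 1 to compound 3 (2.64 log units; beyond the scatter), both large, showing that a chlorine-bearing ring at this position gives far lower numbers than plain phenyl, while a 4.8-fold higher number from compound 2 to compound 3 (0.68 log units; beyond the scatter) shows that moving the fluorine changes the number only modestly. For the measured compounds named here, no measured compound carries a ring nitrogen in this ring, so that part of the change is untested; the chlorine is retained. A modest step at most is expected: a 1.7-fold higher number from compound 3 to compound 4 (0.24 log units; within the scatter). Compound 4 is estimated at 400 nM, with a range of 100 nM to 2000 nM in this assay.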

Compound 4, half-maximal effective concentration: 200 nM
The estimate for compound 4 lay 2.0-fold (0.30 log units) above the measured number; measured number inside the range.
By their numbers in this assay, from the lowest: compound 2; then compounds 4 and 3 (each within the scatter of the next); then compound 1.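

The 3-chloropyridin-4-yl ring, with a ring nitrogen and no fluorine, holds the number set by the 2-chloro-3-fluorophenyl ring (a 1.2-fold lower number from compound 3 to compound 4 (0.06 log units; within the scatter)), so neither fluorine nor a carbon-only ring is required for a low number at this position. The gain over phenyl persists (a 500-fold lower number from compound 1 to compound 4 (2.70 log units; beyond the scatter)), although the 2-chloro-6-fluorophenyl ring still gives the lower number (a 4.2-fold higher number from compound 2 to compound 4 (0.62 log units; beyond the scatter)). Nothing at hand gives a reason for these differences.

As far as these compounds go, what the chlorine itself contributes remains open: compounds 2, 3 and 4 all carry it. A methyl or methoxy group in its place would separate that contribution.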